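The compounds below may be only part of what the source reports. "The series", "measured", "known", "first", "only" and "open" are said of these compounds alone.

In a functional assay on WI-38 VA13 cells (Homo sapiens) for cytotoxicity (a lower number here means that less compound is needed, a higher number that more compound is needed for the effect), compound 3 `O=C(Nc1ccc2nc(NC(=O)C3CC3)sc2c1)c1c(Cl)cccc1Cl` gives 0.013 ug/mL. Compound 1 `Cc1[nH][n+](C)c(C)c1C(=O)Nc1ccc2nc(NC(=O)C3CCCCC3)sc2c1` gives 0.012 ug/mL in this assay, and the two numbers lie within the scatter of each other, so nothing separates them. Compound 2 `Cc1cccc(C)c1NC(=O)Nc1ccc2nc(NC(=O)C3CCCCC3)sc2c1` gives 0.56 ug/mL in this assay, well apart from both. Among the compounds with values here, the one measured step, a 47-fold higher number from compound 1 to compound 2 (1.67 log units; beyond the scatter), concerns the group on a different carbonyl carbon of the shared core, the one attached to the aryl amide, and does not touch the place where compound 4 differs. Compound 4 `CC(C)OC(=O)Nc1nc2ccc(NC(=O)c3c(Cl)cccc3Cl)cc2s1` arises from compound 3 by the change (isopropoxy in place of cyclopropyl on a carbonyl carbon). Within the data shown here, no measured step bears on the cyclopropylcarbonyl group; compound 1 carries a cyclohexyl group there, but it also differs from compound 3 in a second place, so its number alone says nothing about this position. With nothing pointing either way, the step expected is a 1.5-fold higher number from compound 3 to compound 4 (0.19 log units; within the scatter), within the scatter. Compound 4 is therefore estimated at 0.02 ug/mL, in the range 0.005 ug/mL to 0.08 ug/mL.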

Compound 4, half-maximal effective concentration: 0.0026 ug/mL
Estimate against measurement, compound 4: 7.7-fold (0.89 log units) above; measured number below the stated range.
By their numbers in this assay, from the lowest: compound 4; then compounds 1 and 3 (each within the scatter of the next); then compound 2.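

The group on the carbonyl carbon bound to the amide-type nitrogen matters in this assay: with isopropoxy in place of cyclopropyl, the result is a 5.0-fold lower number from compound 3 to compound 4 (0.70 log units; beyond the scatter), a step beyond the scatter. The earlier compounds shown here gave no reading of this position, and this pair shows that an open-chain group with one hydrogen-bond acceptor and no ring is tolerated there and lowers the number. No measurement among these compounds accounts for the step. The compounds shown leave open whether the oxygen or the loss of the ring goes with this step, which a plain isopropyl group or a dimethylamino group on the same carbonyl carbon would help to separate. They also leave open whether the same change would lower the number on compound 1, which carries cyclohexyl there.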